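A Hydroxy Swap on the Propyl Chain of Compound 3

The compounds below may be only part of what the source reports. "The series", "measured", "known", "first", "only" and "open" are said of these compounds alone.

Values in a functional assay on cells (Homo sapiens) for antiproliferative activity, read by MTT assay, with a stated time of 48 h (a higher number here means a weaker inhibitor, a lower number a stronger inhibitor), stand as follows:
Compound 1 `Cn1c(N)c(-c2nc3ccccc3[nH]2)c2nc(C#N)c(C#N)nc21` gives > 50000 nM as a limit
Compound 2 `CCN(CC)CCn1c(N)c(-c2nc3ccccc3[nH]2)c2nc(C#N)c(C#N)nc21` gives 25400 nM
Compound 3 `CN(C)CCCn1c(N)c(-c2nc3ccccc3[nH]2)c2nc(C#N)c(C#N)nc21` gives 1820 nM

Compound 3 holds the lowest number here, and its nearest neighbour is reached by a 14-fold lower number from compound 2 to compound 3 (1.14 log units; beyond the scatter) as the step. The value of compound 1 is a limit and not a number. Even so, the floor of the gap to it is clear in an at least 27-fold lower number from compound 1 to compound 3 (1.43 log units; beyond the scatter) as a step.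

Compound 4 `N#Cc1nc2c(-c3nc4ccccc4[nH]3)c(N)n(CCCO)c2nc1C#N` has 3-hydroxypropyl in place of 3-(dimethylamino)propyl, a change counted as hydroxy in place of dimethylamino on a saturated chain carbon, three bonds along the chain from an aromatic nitrogen and amounting to hydroxy in place of dimethylamino on a saturated chain carbon. For the measured compounds named here, no measured step makes this swap. The two large steps into compound 3 are the nearest guides, and they suggest that much of its standing could be lost. Compound 2 at 25400 nM shows that a dialkylamino chain alone does not secure a low number. A large rise is therefore expected, estimated as a 9.9-fold higher number from compound 3 to compound 4 (1.00 log units; beyond the scatter) in this assay as the step. The estimate for compound 4 is 18000 nM with an expected range from 5000 nM to 50000 nM as its ends.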

Compound 4, half-maximal inhibitory concentration: > 50000 nM
Compound 4 gave a limit, no number (the forecaster's own chance of this, stated with the estimate: 25%); middle value at least 2.7-fold (0.44 log units) from the limit.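

In this assay the value of compound 4 is a limit and not a number, as is that of compound 1: the limit of > 50000 nM in this assay, at which 2 of the 4 values shown sit.

The earlier steps shown here changed the chain and its amine together, whereas hydroxy in place of dimethylamino alters only the end group on a saturated chain carbon, three bonds along the chain from an aromatic nitrogen, and this gives an at least 27-fold higher number from compound 3 to compound 4 (1.43 log units; beyond the scatter). The second readable step, an at least 1.9-fold higher number from compound 2 to compound 4 (0.29 log units; that floor lies within the scatter), has a floor that lies within the scatter and sets no order, and the step that joins the two limits cannot be read.

The compounds shown leave open whether a primary amine or methoxy at this place would keep a number near that of compound 3 at 1820 nM. They also leave open how dimethylamino would fare on a longer chain.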